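Swapping the amide aryl group: from nitro to chloro

A few compounds are considered here, and "the series" means these few. Any claim that something is new, unique, unknown or untested is made for them only; others in the source may bear on it.

Measured so far in a functional assay on PC-3 cells (Homo sapiens) for inhibition, read by MTT assay, with a stated time of 72 h; a lower number here means a stronger inhibitor, a higher number a weaker inhibitor:
compound 1 `O=C(CSc1nc(Nc2ccccc2)c2ccccc2n1)Nc1ccccc1F` gives 12400 nM
compound 2 `O=C(CSc1nc(Nc2ccccc2)c2ccccc2n1)Nc1cccc([N+](=O)[O-])c1` gives 11800 nM

Compound 2 gives the lower of the two numbers, but the step of a 1.1-fold lower number from compound 1 to compound 2 (0.02 log units; within the scatter) lies within the scatter, so the pair shows no real difference. Compound 3 `O=C(CSc1nc(Nc2ccccc2)c2ccccc2n1)Nc1ccc(Cl)cc1` differs from compound 2 by 4-chlorophenyl in place of 3-nitrophenyl on an amide-type nitrogen. For the measured compounds named here, the only step that bears on this change is a 1.1-fold lower number from compound 1 to compound 2 (0.02 log units; within the scatter), where exchanging one aryl group for another on the amide-type nitrogen left the number unchanged. A step of similarly negligible size is therefore expected, a 1.1-fold lower number from compound 2 to compound 3 (0.03 log units; within the scatter), in no direction beyond the scatter. Compound 3 is estimated at 11000 nM, within 4500 nM to 27000 nM.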

Compound 3, half-maximal inhibitory concentration: 12900 nM
Compound 3: the middle estimate sits 1.2-fold (0.07 log units) below what was measured; the measured number falls inside the stated range.
By their numbers in this assay, from the lowest: compounds 2, 1 and 3 (each within the scatter of the next).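

In this assay 4-chlorophenyl on the amide-type nitrogen gives a 1.1-fold higher number from compound 2 to compound 3 (0.04 log units; within the scatter) and a 1.0-fold higher number from compound 1 to compound 3 (0.02 log units; within the scatter) so a third aryl group also makes no real difference. All three compounds now lie within the scatter of one another, which a single pair could not show for this position. Nothing here offers an explanation for this lack of difference. The compounds shown leave open whether something other than a substituted phenyl ring on this nitrogen, such as an amine, a carboxylic acid or a longer chain, would shift the number beyond the scatter.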